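Three leucine-chain peptides and a tetrahydropyridine replacement

The source may hold more compounds than are shown below. What is called first, only, known or untested is meant among the compounds shown, and "the series" means these compounds.

Measured so far:
- compound 1, `COC(=O)C12CC1CCN(C(=O)[C@H](CC(C)C)NC(=O)[C@H](CO)NC(=O)[C@@H](NC(=O)OCc1ccccc1)C(C)C)C2`: 2.47 h
- compound 2, `COC(=O)C12CC1CCN(C(=O)[C@H](CC(C)C)NC(=O)[C@H](CC(C)C)NC(=O)[C@H](CC(C)C)NC(=O)OCc1ccccc1)C2`: 3.22 h
- compound 3, `COC(=O)C12CC1CCN(C(=O)[C@H](CC(C)C)NC(=O)[C@H](CC(C)C)NC(=O)[C@H](CC(C)C)NC(=O)c1cccc(O)c1C)C2`: > 6 h

In an ADME assay on a cell-free system (plasma, Homo sapiens) for metabolic stability (a lower number here means that the compound disappears faster, a higher number that the compound lasts longer), compound 1 gives 2.47 h and compound 2 gives 3.22 h. For compound 3 the result is not a number but a limit of the assay, > 6 h (the limit of > 6 h in this assay, at which 1 of the 3 values shown sits). So compound 3 stands at the top of what the method can report, and the step of an at least 1.8-fold higher number from compound 2 to compound 3 (0.27 log units; that floor lies within the scatter) is known only as a floor.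

Compound 4, `COC(=O)C12CC1CCN(C(=O)[C@H](CC(C)C)NC(=O)[C@H](CC(C)C)NC(=O)[C@H](CC(C)C)NC(=O)C1=CCCNC1)C2`, differs from compound 3 in one place: a group of 6 heavy atoms (5 carbon, 1 nitrogen; one six-membered non-aromatic ring with 1 hetero atom) in place of a group of 8 heavy atoms (7 carbon, 1 oxygen; one six-membered aromatic ring of carbon only), on a carbonyl carbon. In words, a group of 6 heavy atoms (5 carbon, 1 nitrogen; one six-membered non-aromatic ring with 1 hetero atom) replaces a group of 8 heavy atoms (7 carbon, 1 oxygen; one six-membered aromatic ring of carbon only), on a carbonyl carbon.

Among the compounds with values here, only one measured step touches this position, the one from compound 2 to compound 3, and it is itself open-ended. Within the data shown here, no measured pair shows what the entering ring does. The expectation for compound 4 in this assay is therefore a number near that of compound 3, with the step of an at least 1.2-fold lower number from compound 3 to compound 4 (0.07 log units; that floor lies within the scatter) expected to be small, and a fair chance that the assay again reports only a limit. The estimate for compound 4 is 5 h, with a range from 2.5 h to 10 h.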

Compound 4, half-life: > 6 h
Compound 4 was reported as a limit; the forecaster's own chance of this, stated with the estimate: 40%; middle value at least 1.2-fold (0.07 log units) away from the limit.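

Compound 4 also sits at the top of what this assay can report: the limit of > 6 h in this assay, at which 2 of the 4 values shown sit.

Compound 3 and compound 4 are both limits, so the step between them cannot be read and the two ring groups cannot be ranked against each other. What is new is that the 3-hydroxy-2-methylphenyl group is not needed to reach this limit: a six-membered non-aromatic ring containing a nitrogen, on the same carbonyl carbon, reaches it too, and putting this ring in place of the benzyloxy group gives an at least 1.8-fold higher number from compound 2 to compound 4 (0.27 log units; that floor lies within the scatter).

As far as these compounds go, how far compound 3 and compound 4 lie past the limit remains open, and so does the true size of the gain over the benzyloxy group, which is known only as a floor. Also open, from the compounds shown here alone, is whether a fully saturated piperidine ring, an open-chain amine or a carboxylic acid at this position would reach the same limit, which would show whether the ring, its double bond or its nitrogen matters here.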